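The source may report more compounds than this note shows. Statements on the series, on what has been measured and on what is new or still open speak of the compounds shown alone.

Measured so far:
compound 1 `COc1cc(C2=NOC(CO[C@@H]3O[C@H](CSc4ncn[nH]4)[C@H]4OC5(CCCC5)O[C@@H]34)C2)cc(OC)c1OC`: 55000 nM
compound 2 `Nc1nnc(SC[C@H]2O[C@@H](OCc3noc(-c4ccc(Cl)cc4)n3)[C@@H]3OC4(CCCC4)O[C@@H]32)s1`: 18000 nM

In a functional assay on T47D cells (Homo sapiens) for antiproliferative activity, read by sulforhodamine B assay, with a stated time of 48 h (on this read-out lower numbers stand for stronger inhibition of growth and higher numbers for weaker inhibition of growth), compound 2 holds the lower of the two numbers; compound 1 stands higher, beyond the scatter, but the two cores differ in more than one place, so no single step can be read from them. Compound 3 `Clc1ccc(-c2nc(CO[C@@H]3O[C@H](CSc4ncn[nH]4)[C@H]4OC5(CCCC5)O[C@@H]34)no2)cc1` keeps the core of compound 2 with one change: 1H-1,2,4-triazol-5-yl in place of 5-amino-1,3,4-thiadiazol-2-yl on a sulfur. Among the measured compounds shown here, no measured pair shows this exchange on its own. Expectation: a step of a 1.4-fold higher number from compound 2 to compound 3 (0.14 log units; within the scatter), small and not beyond the scatter, if anything toward weaker inhibition. Compound 3 is estimated at 25000 nM, range 8000 nM to 80000 nM.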

Compound 3, concentration for 50% growth inhibition: 10000 nM
Compound 3: the middle estimate sits 2.5-fold (0.40 log units) above what was measured; measured number inside the range.
By their numbers in this assay, from the lowest: compounds 3 and 2 (each within the scatter of the next); then compound 1.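

The exchange of 5-amino-1,3,4-thiadiazol-2-yl for 1H-1,2,4-triazol-5-yl on a sulfur reads a 1.8-fold lower number from compound 2 to compound 3 (0.26 log units; within the scatter) in this assay, the only single-place comparison shown in the series. At this position, the read-out does not separate these two five-membered aromatic rings, each with 3 hetero atoms. No supporting data bear on this result. Open, from the compounds shown here alone, is whether a different kind of group on this sulfur, such as a carboxylic acid, an amine or a longer alkyl chain, would give a step beyond the scatter.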